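Methyl addition on the five-membered ring: working notes

This account rests on a few compounds, and the source may have more. Where it says the series, first, only, none or still open, it means among the compounds named here.

Measured compounds in a functional assay on RKO cells (Homo sapiens) for cytotoxicity, read by resazurin assay, with a stated time of 72 h; on this read-out higher numbers stand for weaker inhibition and lower numbers for stronger inhibition:
compound 1, `COc1cccc(Nc2nc(-n3cc(C)nc3C)cs2)c1`: 22500 nM
compound 2, `Cc1ccc(Nc2nc(-n3ccnc3C)cs2)cc1`: 450 nM
compound 3, `COc1cccc(Nc2nc(-n3ccnc3C)cs2)c1`: 22500 nM

The step from compound 3 to compound 1 is methyl in place of hydrogen on an aromatic carbon and gives no change at the digits printed from compound 3 to compound 1 (within the scatter). Compound 2 stands lowest of the three in this assay; the difference between the core of compound 2 and the core of compound 3 is not broken down here.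

Compound 4, `Cc1ccc(Nc2nc(-n3cc(C)nc3C)cs2)cc1`, is not yet measured. It differs from compound 2 by methyl in place of hydrogen on an aromatic carbon, the same change as from compound 3 to compound 1. Because no change at the digits printed from compound 3 to compound 1 (within the scatter), the step from compound 2 to compound 4 is expected to be no change at the digits printed from compound 2 to compound 4 (within the scatter), within the scatter. Compound 4 is therefore estimated at 450 nM in this assay, between 180 nM and 1100 nM. This rests on a single precedent and could shift.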

Compound 4, half-maximal inhibitory concentration: 200 nM
Estimate against measurement, compound 4: 2.3-fold (0.35 log units) above, within the range that was stated.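

In this assay, methyl in place of hydrogen on an aromatic carbon of the five-membered ring gives a 2.3-fold lower number from compound 2 to compound 4 (0.35 log units; beyond the scatter) on the core of compound 2. Set beside the earlier step, the two results do not separate: the same change on two cores in this assay, no change at the digits printed (within the scatter) from compound 3 to compound 1 and a 2.3-fold lower number (0.35 log units; beyond the scatter) from compound 2 to compound 4, 2.3-fold (0.35 log units) apart, within the scatter of two such steps. The change therefore carries across these two cores without a gap that stands clear of the scatter, but this does not show that it would carry to any further core in the series.

The compounds shown leave open whether a longer chain, such as ethyl, or an amine or a carboxylic acid in the same place would give a step like that of methyl.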